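Amino Added to the Core of Compound 1

The compounds below may be only part of what the source reports. "The series", "measured", "known", "first", "only" and "open" are said of these compounds alone.

In a functional assay on L1210 cells (Mus musculus) (on this read-out lower numbers stand for stronger inhibition and higher numbers for weaker inhibition), compound 1 `NC(=O)c1ccn(C2O[C@H](CO)[C@@H](O)[C@H]2O)n1` gives only a limit of > 1030 uM, not a number. Compound 2 `CCCCCn1nnc2c(C)nn(C3O[C@H](CO)[C@@H](O)[C@H]3O)c2c1=O` likewise gives only a limit, > 1400 uM. Compound 1 thus stands at the limit of > 1030 uM in this assay, at which 1 of the 2 values shown sits, with no numerical value to place it against anything else.

Compound 3 `NC(=O)c1nn(C2O[C@H](CO)[C@@H](O)[C@H]2O)cc1N` differs from compound 1 by amino in place of hydrogen on an aromatic carbon. Among the measured compounds shown here, no measured step covers such a change, so no shift beyond the scatter is expected in this assay. Compound 3 is estimated at 1000 uM, between 200 uM and 3000 uM, an expected step of an at least 1.0-fold lower number from compound 1 to compound 3 (0.01 log units; that floor lies within the scatter).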

Compound 3, concentration for 50% inhibition: > 1830 uM
Compound 3 gave a limit, no number (the forecaster's own chance of this, stated with the estimate: 80%); middle value at least 1.8-fold (0.26 log units) from the limit.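

Among the compounds shown here, compound 1 and compound 3 both give only limits in this assay, and no step between them can be read. The compounds shown leave open whether amino in place of hydrogen changes inhibition at all.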